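The source may report more compounds than this note shows. Statements on the series, on what has been measured and on what is new or still open speak of the compounds shown alone.

Compound 1 `Cn1cc(C2CC(c3ccccc3)=NN2C(=O)c2cccnc2)c2cc(Br)ccc21` and compound 2 `COc1ccc2c(c1)c(C1CC(c3ccccc3)=NN1C(=O)c1cccnc1)cn2C` share one core. In a functional assay on HeLa cells (Homo sapiens) for inhibition, read by MTT assay, with a stated time of 48 h (a higher number here means a weaker inhibitor of growth, a lower number a stronger inhibitor of growth), compound 1 gives 1730 nM, while compound 2 gives 3590 nM. The change between them, (methoxy in place of bromo on an aromatic carbon), made the step of a 2.1-fold higher number from compound 1 to compound 2 (0.32 log units; beyond the scatter). Compound 3 `COc1ccc2c(c1)c(C1CC(c3ccc(Br)cc3)=NN1C(=O)c1ccc(OC)nc1)cn2C` is built on a core whose difference from compound 1 is not broken down here. In this assay compound 3 gives only a limit, > 10000 nM, namely (the limit of > 10000 nM in this assay, at which 1 of the 3 values shown sits). Compound 4 `COc1ccc(C2=NN(C(=O)c3ccc(OC)nc3)C(c3cn(C)c4ccc(OC)cc34)C2)cc1` differs from compound 3 by methoxy in place of bromo on an aromatic carbon, the same kind of change as from compound 1 to compound 2, though here the place is para to a large group rather than meta and para to a fused ring. The step from compound 3 to compound 4 is expected to be a step that the limit leaves unreadable from compound 3 to compound 4, resting on the earlier step of a 2.1-fold higher number from compound 1 to compound 2 (0.32 log units; beyond the scatter). Compound 4 is therefore expected to give about 20000 nM, somewhere between 10000 nM and 50000 nM.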

Compound 4, concentration for 50% growth inhibition: 180 nM
Estimate against measurement, compound 4: 110-fold (2.05 log units) above; measured number outside the range, below it.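

In this assay, the same swap of bromo for methoxy gives an at least 55-fold lower number from compound 3 to compound 4 (1.74 log units; beyond the scatter), so its result on the core of compound 1 does not carry over to the core of compound 3: the same change on two cores in this assay, a 2.1-fold higher number (0.32 log units; beyond the scatter) from compound 1 to compound 2 and an at least 55-fold lower number (1.74 log units; beyond the scatter) from compound 3 to compound 4, at least 110-fold (2.06 log units) apart, beyond the scatter of two such steps. Compound 3 gives only a limit, > 10000 nM, so this step has no exact size. The two pairs also differ in where the swap sits, so these compounds cannot show whether that place or another part of the core sets the outcome.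

The compounds shown leave open how other groups would behave at this spot on the core of compound 3. An amine or a carboxylic acid in place of the methoxy, for example, could show whether the result is particular to methoxy.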